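This account rests on a few compounds, and the source may have more. Where it says the series, first, only, none or still open, it means among the compounds named here.

Series: a shared core bearing two dodecyloxy chains, varied at the amine end. Compound 1 `CCCCCCCCCCCCOCC(CN)OCCCCCCCCCCCC` is the free amine; compound 2 `CCCCCCCCCCCCOCC(CNC(=O)[C@@H](N)CCCCN)OCCCCCCCCCCCC` carries the (1,5-diaminopentyl)carbonyl group on that nitrogen. In a functional assay on V79 cells (Cricetulus griseus) for cytotoxicity (on this read-out lower numbers stand for stronger inhibition and higher numbers for weaker inhibition), compound 1 gives 75000 nM, and compound 2 gives 34000 nM. Among the measured compounds shown here, the only step measured so far, a 2.2-fold lower number from compound 1 to compound 2 (0.34 log units; beyond the scatter), puts compound 2 at the lowest of the two numbers in this assay, with compound 1 the nearest neighbour.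

Compound 3 `CCCCCCCCCCCCOCC(CNC(=O)[C@@H](N)CCCN=C(N)N)OCCCCCCCCCCCC` is not yet measured. It differs from compound 2 by a group of 4 heavy atoms (1 carbon, 3 nitrogen; no ring) in place of a group of 2 heavy atoms (1 carbon, 1 nitrogen; no ring), on a saturated chain carbon, four bonds along the chain from an amine nitrogen and a carbonyl carbon. For the measured compounds named here, no measured step in this assay touches this kind of exchange: the one step on record concerns the addition of the whole (1,5-diaminopentyl)carbonyl group and says nothing about reshaping its end. The shown numbers therefore give no direction for this assay, and the expectation is a step within the scatter in either sense. For compound 3 the expected value in this assay is 30000 nM, with a range of 12000 nM to 75000 nM. This estimate means a step of a 1.1-fold lower number from compound 2 to compound 3 (0.05 log units; within the scatter), expected to stay within the scatter.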

Compound 3, half-maximal inhibitory concentration: 20000 nM
Compound 3: middle estimate off by 1.5-fold (0.18 log units), on the high side, within the range that was stated.
By their numbers in this assay, from the lowest: compounds 3 and 2 (each within the scatter of the next); then compound 1.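

In this assay, the group of 4 heavy atoms in place of aminomethyl, on a saturated chain carbon, four bonds along the chain from an amine nitrogen and a carbonyl carbon, gives a 1.7-fold lower number from compound 2 to compound 3 (0.23 log units; within the scatter) and so leaves the read-out within the scatter: at this place, the exchange does not separate compound 3 from compound 2. Measured against the free amine, the whole group of 11 heavy atoms on the amine nitrogen gives a 3.8-fold lower number from compound 1 to compound 3 (0.57 log units; beyond the scatter) and stays beyond the scatter, so both substituted compounds shown, compound 2 and compound 3, now lie apart from compound 1 by steps of modest size. No measured evidence bears on the reason for either step.

Still open, going by these compounds, is whether a carboxylic acid or a hydroxyl group at this same chain end would stay within the scatter of compound 2, or whether a shorter or longer chain carrying the aminomethyl or the new group would move the number further. The part played by the two dodecyloxy chains is also open, since every compound shown carries them, and an octyloxy or hexadecyloxy chain would test how far the numbers depend on that length.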